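From Propyl Ester to Primary Amide on a Shared Core

The source may hold more compounds than are shown below. What is called first, only, known or untested is meant among the compounds shown, and "the series" means these compounds.

Compound 1 `CCCOC(=O)c1cnc2ccccc2n1` gives 1.41 in a physicochemical assay for lipophilicity; on this read-out lower numbers stand for lower lipophilicity and higher numbers for higher lipophilicity.
Compound 2 `CCCCCCCCOC(=O)c1cnc2ccccc2n1` gives 2.61 in this assay.
Compound 3 `CCCCCCC(C)OC(=O)c1cnc2ccccc2n1` gives 2.7 in this assay.

Compound 1 stands lowest of these three numbers; compound 2 lies beyond the scatter above it, and compound 3 lies further above still. Compound 4 `NC(=O)c1cnc2ccccc2n1` differs from compound 1 by amino in place of propoxy on a carbonyl carbon. For the measured compounds named here, no measured pair swaps an ester for an amide, so the change itself has no direct precedent here. The step that comes nearest is a number 1.20 log units higher from compound 1 to compound 2 (beyond the scatter), where lengthening the chain raised the number. Removing the propoxy entirely and bringing in an amino group is expected to run the other way, by more than the scatter. Compound 4 is therefore estimated at -0.5, between -1.4 and 0.4, an expected step of a number 1.91 log units lower from compound 1 to compound 4 (beyond the scatter).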

Compound 4, partition coefficient: 0.13
Compound 4: middle estimate off by 0.63 log units, on the low side; measured number inside the range.
By their numbers in this assay, from the lowest: compound 4; then compound 1; then compounds 2 and 3 (each within the scatter of the next).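

Putting amino in place of propoxy on a carbonyl carbon gives a number 1.28 log units lower from compound 1 to compound 4 (beyond the scatter) in this assay. The earlier compounds shown here showed only a change along the ester chain, where the number rose, whereas here the whole group on the carbonyl carbon is exchanged and the number falls. Nothing available explains this drop. 

Going by these compounds, whether the step follows from the entering amino or from the departing propoxy stays open. Also open, on these data alone, is how a carboxylic acid or a butylamino group on the same carbonyl carbon would read.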